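The compounds below may be only part of what the source reports. "The series", "measured", "known", "first", "only" and "open" are said of these compounds alone.

In a physicochemical assay for metabolic stability, read by HPLC, in phosphate buffer, at pH 7.4, tested at 10 uM (on this read-out lower numbers stand for a shorter-lived compound and higher numbers for a longer-lived compound), compound 1 `O=C(NCCCCc1ccccc1)n1c(=O)oc2ccccc21` gives 0.75 h, the lowest number among the measured compounds. Compound 4 `O=C(NCCCCc1ccccc1)n1c(=O)oc2cc(-c3ccccc3)ccc21` has phenyl in place of hydrogen on an aromatic carbon. Two measured compounds carry a substituted version of this group. Compound 3 `COc1ccc(-c2ccc3c(c2)oc(=O)n3C(=O)NCCCCc2ccccc2)cc1`, with 4-methoxyphenyl, gives 2.2 h, which is a 2.9-fold higher number from compound 1 to compound 3 (0.47 log units; beyond the scatter). Compound 2 `O=C(NCCCCc1ccccc1)n1c(=O)oc2cc(-c3ccc(F)cc3)ccc21`, with 4-fluorophenyl, reads > 5 h, which is a limit of the assay and not a number. Its step is an at least 6.6-fold higher number from compound 1 to compound 2 (0.82 log units; beyond the scatter). Both steps go upward and beyond the scatter, so a rise of similar size is expected here. The expected step is a 4.0-fold higher number from compound 1 to compound 4 (0.60 log units; beyond the scatter). For compound 4 the estimated value is 3 h, with an expected range of 1.5 h to 6.5 h.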

Compound 4, half-life: > 5 h
Compound 4 was reported as a limit; the forecaster's own chance of this, stated with the estimate: 30%; middle value at least 1.6-fold (0.22 log units) away from the limit.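

In this assay unsubstituted phenyl gives an at least 6.6-fold higher number from compound 1 to compound 4 (0.82 log units; beyond the scatter), so the rise at this position needs no substituent on the added ring. Putting hydrogen back in place of methoxy gives an at least 2.2-fold higher number from compound 3 to compound 4 (0.35 log units; beyond the scatter), which shows that the methoxy group goes with the lower number of the two. The step between compound 2 and compound 4 cannot be read because both stand at the same limit: the limit of > 5 h in this assay, at which 2 of the 4 values shown sit.

As far as these compounds go, how far past that limit either compound lies stays open. So does whether an amine or a carboxylic acid in this place would also raise the number.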